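The source may report more compounds than this note shows. Statements on the series, on what has been measured and on what is new or still open speak of the compounds shown alone.

Measured in a functional assay on HL-60 cells (Homo sapiens) for inhibition, read by CCK-8 assay, with a stated time of 48 h; on this read-out higher numbers stand for weaker inhibition and lower numbers for stronger inhibition:
- compound 1 `O=[N+]([O-])c1ccc(NC(=S)NCCNS(=O)(=O)c2ccc(-c3ccccc3OCc3cccc(O)c3)s2)cc1` gives 10800 nM
- compound 2 `Cc1cc(C)cc(NC(=O)NCCNS(=O)(=O)c2ccc(-c3ccccc3OCc3cccc(O)c3)s2)c1` gives > 20000 nM as a limit of the assay

On these data alone, compound 2 stands at a limit, not at a number, so its true position is unknown. Compound 3 `COc1ccc(NC(=O)NCCNS(=O)(=O)c2ccc(-c3ccccc3OCc3cccc(O)c3)s2)cc1` carries 4-methoxyphenyl in place of 3,5-dimethylphenyl on an amide-type nitrogen, counted as 4-methoxyphenyl in place of 3,5-dimethylphenyl on an amide-type nitrogen. Among the compounds with values here, the only measured step is an at least 1.8-fold higher number from compound 1 to compound 2 (0.26 log units; that floor lies within the scatter). It concerns a different change, and its floor lies within the scatter, so it gives no measured size for this swap. No shift beyond the scatter is expected in this assay, and the expected at least 1.1-fold lower number from compound 2 to compound 3 (0.04 log units; that floor lies within the scatter) is small. Compound 3 is estimated at 18000 nM, with an expected range from 9000 nM to 30000 nM.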

Compound 3, half-maximal inhibitory concentration: > 20000 nM
Compound 3 was reported as a limit; the forecaster's own chance of this, stated with the estimate: 60%; middle value at least 1.1-fold (0.04 log units) from the limit.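

In this assay compound 3 gives > 20000 nM, which is a limit of the assay and not a number. 4-Methoxyphenyl on the amide-type nitrogen therefore ends at the same limit as 3,5-dimethylphenyl, and the step between the two cannot be read: the limit of > 20000 nM in this assay, at which 2 of the 3 values shown sit. Within the data shown here, the one readable step is an at least 1.8-fold higher number from compound 1 to compound 3 (0.26 log units; that floor lies within the scatter), so no shift beyond the scatter is established.

Which part of the group on compound 1 accounts for its number stays open. Also open, on these data alone, is whether an amine or a carboxylic acid on this aryl ring would give a value clear of the limit.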